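This account rests on a few compounds, and the source may have more. Where it says the series, first, only, none or still open, it means among the compounds named here.

Measured compounds in an assay on isolated protein for inhibition of transmembrane protease serine 11D (Homo sapiens), read by fluorescence; on this read-out higher numbers stand for weaker inhibition and lower numbers for stronger inhibition:
- compound 1 `CC(C)N1CCN(C(=O)C[C@@H](NS(=O)(=O)Cc2ccccc2)C(=O)N2CCC[C@H]2C(=O)NCc2ccc(C(=N)N)cc2)CC1`: 221 nM
- compound 2 `CC[C@H](C)[C@H](NCc1ccc(C(=N)N)cc1)C(=O)[C@@H](CCCNC(=N)N)NS(=O)(=O)Cc1ccccc1`: 23 nM

For the measured compounds named here, two measured compounds so far. Compound 2 gives the lower of the two numbers in this assay, and the gap from compound 2 up to compound 1 lies beyond the usual scatter, so compound 2 stands as the stronger inhibitor of the pair. Compound 1 and compound 2 differ in many places at once, so nothing can be read from them about any single change.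

Compound 3 `CC(C)(C)OC(=O)C[C@H](NCc1ccc(C(=N)N)cc1)C(=O)[C@@H](CCCNC(=N)N)NS(=O)(=O)Cc1ccccc1` is not yet measured. It differs from compound 2 in one place: (tert-butoxycarbonyl)methyl in place of sec-butyl on a saturated chain carbon bound to an amine nitrogen and a carbonyl carbon. Going by the values given here, no measured pair shows this change, so the direction and size of the step rest on no observed precedent. The expectation is a modest weakening or no change beyond the scatter: the step from compound 2 to compound 3 is estimated at a 2.2-fold higher number from compound 2 to compound 3 (0.34 log units; beyond the scatter). For compound 3 in this assay the estimate is 50 nM, with a range from 15 nM to 200 nM, the width reflecting the absence of any measured step for this change.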

Compound 3, inhibition constant: 512 nM
The estimate for compound 3 lay 10-fold (1.01 log units) below the measured number, outside the stated range (above it).
By their numbers in this assay, from the lowest: compound 2; then compound 1; then compound 3.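

In this assay, placing (tert-butoxycarbonyl)methyl in place of sec-butyl on the saturated chain carbon bound to an amine nitrogen and a carbonyl carbon gives a 22-fold higher number from compound 2 to compound 3 (1.35 log units; beyond the scatter), the first single-place step available in this series and a large one. It shows that inhibition depends strongly on the group at this position, and that this exchange, which adds heavy atoms and two hydrogen-bond acceptors, moves the series towards weaker inhibition. No measurement available here bears on the origin of this step.

One step cannot separate the contribution of the ester from that of the added atoms or the tert-butyl end, nor show whether sec-butyl is close to the best group at this position. Carboxymethyl, which carries a free carboxylic acid, methoxycarbonylmethyl and an all-carbon chain such as n-hexyl would each bear on these questions, while an aminoalkyl chain would test whether a basic amine is tolerated at the same carbon.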